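This account rests on a few compounds, and the source may have more. Where it says the series, first, only, none or still open, it means among the compounds named here.

Working notes on the series. Among the measured compounds shown here, in an ADME assay on microsomes from liver (Homo sapiens) for metabolic stability, using NADPH, with a stated time of 60 min (a lower number here means slower removal, a higher number faster removal of the compound), compound 2 `O=C(Nc1ccc(F)c(C(F)(F)F)c1)Nc1cnccn1` gives 210 uL/min, and this is the only number on record here. Compound 1 `O=C(Nc1ccnc(C(F)(F)F)c1)Nc1ccc(F)c(C(F)(F)F)c1` returns in this assay only a limit, < 7 uL/min, as noted in the limit of < 7 uL/min in this assay, at which 1 of the 2 values shown sits. Compound 3 `O=C(Nc1cccnc1)Nc1ccc(F)c(C(F)(F)F)c1` differs from compound 2 by pyridin-3-yl in place of pyrazin-2-yl on an amide-type nitrogen. For the measured compounds named here, no measured step connects these two compounds. The step from compound 2 to compound 3 in this assay is expected to be small, not beyond the usual scatter: a 1.4-fold lower number from compound 2 to compound 3 (0.15 log units; within the scatter). Compound 3 is therefore estimated at 150 uL/min in this assay, within a likely range of 50 uL/min to 450 uL/min.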

Compound 3, intrinsic clearance in a liver preparation (reported as CLH), per the amount of preparation that the assay uses in the Homo sapiens assay: 13 uL/min
For compound 3 the middle estimate is 12-fold (1.06 log units) above the measured one, outside the stated range (below it).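

Among the compounds shown here, the first measured step at this position is large in the Homo sapiens assay: a 16-fold lower number from compound 2 to compound 3 (1.21 log units; beyond the scatter). In a physicochemical assay for lipophilicity, read by HPLC, measured as octanol-water partition, at pH 7.2 (on this read-out lower numbers stand for lower lipophilicity and higher numbers for higher lipophilicity), compound 2 gives 3 and compound 3 gives 3, so this step comes with no change on that read-out: no change at the digits printed from compound 2 to compound 3 (within the scatter). The aromatic ring on the amide-type nitrogen alone can therefore move the clearance number widely.

For the compounds shown here, compound 1 gives only a limit, so no step to it can be read: the limit of < 7 uL/min in the Homo sapiens assay, at which 1 of the 3 values shown sits. From the compounds shown here alone, whether an amine or a methoxy group on the pyridin-3-yl ring would hold the number of compound 3 stays open.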